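The compounds below may be only part of what the source reports. "The series", "measured", "known", "first", "only" and "open" are said of these compounds alone.

Of the compounds shown here, two sharing one core have been measured in a functional assay on A549 cells (Homo sapiens) for cytotoxicity, read by MTT assay, with a stated time of 72 h; on this read-out higher numbers stand for weaker inhibition and lower numbers for stronger inhibition. Compound 1, `O=C(Nc1ccc(Oc2ccnc3[nH]ccc23)cc1)c1cc(-c2ccccc2)ncn1`, gives 140 nM. Compound 2, `O=C(Nc1ccc(Oc2ccnc3[nH]ccc23)c(F)c1)c1cc(-c2ccccc2)ncn1`, gives 180 nM. Going by the values given here, the single step between them, a 1.3-fold higher number from compound 1 to compound 2 (0.11 log units; within the scatter), does not separate the pair. Of the two numbers, compound 2 carries the higher one, yet its gap to compound 1 stays within the scatter, so no ranking between them can be read.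

Compound 3, `Cc1ccc(-c2cc(C(=O)Nc3ccc(Oc4ccnc5[nH]ccc45)c(F)c3)ncn2)cc1`, has not yet been measured. It differs from compound 2 in one place: methyl in place of hydrogen on an aromatic carbon. Among the compounds with values here, no measured step touches this kind of change; the only step at hand, from compound 1 to compound 2, concerns fluoro in place of hydrogen and lies within the scatter, so it neither supports nor argues against a shift here. With nothing pointing in either direction, the step from compound 2 to compound 3 in this assay is expected to be none beyond the scatter, estimated at no change at the digits printed from compound 2 to compound 3 (within the scatter). Compound 3 is accordingly estimated at 180 nM in this assay, with a range from 70 nM to 450 nM.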

Compound 3, half-maximal inhibitory concentration: 8600 nM
The estimate for compound 3 lay 48-fold (1.68 log units) below the measured number; the measured number lies above the stated range.
By their numbers in this assay, from the lowest: compounds 1 and 2 (each within the scatter of the next); then compound 3.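

In this assay, methyl in place of hydrogen on an aromatic carbon, para to a large group on a six-membered aromatic ring of carbon only, gives a large step, a 48-fold higher number from compound 2 to compound 3 (1.68 log units; beyond the scatter), so this position of the phenyl group does not tolerate every substituent, and one added carbon is enough to weaken inhibition well beyond the scatter. The earlier step, a 1.3-fold higher number from compound 1 to compound 2 (0.11 log units; within the scatter), lay elsewhere in the molecule, stayed within the scatter and gave no sign that the change from phenyl to 4-methylphenyl could matter so much. No measurement at hand speaks to what lies behind this step.

The compounds shown leave open whether the weaker inhibition belongs to methyl alone or would also follow from a fluoro, a chloro, a methoxy or an amine on the same carbon, and whether a longer chain there would weaken it further. They also leave open whether methyl would act in the same way on the other carbons of this ring, or on the core of compound 1, which has hydrogen where compound 2 has fluoro.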